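This account rests on a few compounds, and the source may have more. Where it says the series, first, only, none or still open, it means among the compounds named here.

Measured compounds in a functional assay on A549 cells (Homo sapiens) for antiproliferative activity, read by CCK-8 assay, with a stated time of 72 h; a higher number here means a weaker inhibitor, a lower number a stronger inhibitor:
compound 1 `Cc1ccc(C(=O)Nc2cccc(-c3oc4cc(-c5ccc(F)cc5)ccc4c(=O)c3O)c2)cc1`: 6910 nM
compound 2 `Cc1ccccc1C(=O)Nc1cccc(-c2oc3cc(-c4ccc(F)cc4)ccc3c(=O)c2O)c1`: 17600 nM
compound 3 `Cc1cccc(C(=O)Nc2cccc(-c3oc4cc(-c5ccc(F)cc5)ccc4c(=O)c3O)c2)c1`: 16500 nM

Compound 3 sits second highest of the three numbers in this assay. Its nearest neighbour is compound 2, a 1.1-fold lower number from compound 2 to compound 3 (0.03 log units; within the scatter), so the two are indistinguishable here. For the measured compounds named here, the only step that separates anything is the one to compound 1: a 2.4-fold higher number from compound 1 to compound 3 (0.38 log units; beyond the scatter), and the parallel a 2.5-fold higher number from compound 1 to compound 2 (0.41 log units; beyond the scatter). Within this small set, the 4-methylphenyl compound gives the lowest number and both other methylphenyl isomers give modestly higher ones.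

Compound 4 `CCCc1ccc(C(=O)Nc2cccc(-c3oc4cc(-c5ccc(F)cc5)ccc4c(=O)c3O)c2)cc1` is the next member. The change from compound 3: 4-propylphenyl in place of 3-methylphenyl on a carbonyl carbon. Two things happen at once: the substituent returns to the arrangement seen in compound 1, and the methyl is replaced by a propyl chain. The first part is covered by the step from compound 1 to compound 3 read backwards, a modest lowering of the number. Going by the values given here, no measured pair speaks to methyl against propyl on this phenyl, so that part is uncertain. The expectation is therefore a modest fall, a 2.4-fold lower number from compound 3 to compound 4 (0.37 log units; beyond the scatter), landing near the value of compound 1. Compound 4 is estimated at 7000 nM, with a range of 3000 nM to 16000 nM.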

Compound 4, half-maximal inhibitory concentration: 47600 nM
For compound 4 the middle estimate is 6.8-fold (0.83 log units) below the measured one; measured number above the stated range.
By their numbers in this assay, from the lowest: compound 1; then compounds 3 and 2 (each within the scatter of the next); then compound 4.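

Extending the methyl of compound 1 to the propyl chain of compound 4 gives the largest step seen so far on this phenyl ring in this assay (a 6.9-fold higher number from compound 1 to compound 4 (0.84 log units; beyond the scatter)), larger than either step that moved the methyl from the 4-methylphenyl arrangement to another isomer. The 4-propylphenyl group also gives a higher number than both other methylphenyl isomers (a 2.9-fold higher number from compound 3 to compound 4 (0.46 log units; beyond the scatter); a 2.7-fold higher number from compound 2 to compound 4 (0.43 log units; beyond the scatter)), so the 4-substituted arrangement does not by itself give a low number: compound 1 has the lowest value of the four, while compound 4, with its substituent in the same arrangement, has the highest. The data shown offer no independent measurement that accounts for this rise.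

The compounds shown leave open whether the number climbs steadily with chain length, which a 4-ethylphenyl group and a longer chain such as 4-pentylphenyl would show, and whether the rise depends on an all-carbon chain, which an amine or a carboxylic acid at the end of the chain would test. They also leave open how 2-propylphenyl and 3-propylphenyl would compare with compound 4.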